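Three Chain Ends, and a Fourth Still Unmeasured

A few compounds are considered here, and "the series" means these few. Any claim that something is new, unique, unknown or untested is made for them only; others in the source may bear on it.

Values in a functional assay on HCT-116 cells (Homo sapiens) for antiproliferative activity, read by sulforhodamine B assay, with a stated time of 72 h; a lower number here means a stronger inhibitor, a higher number a weaker inhibitor
Compound 1 `Cn1ncc(Cl)c1-c1cc(C(=O)N[C@@H]2CN[C@H](CC(O)CO)C[C@H]2c2ccc(Cl)c(Cl)c2)oc1Cl` gives 1110 nM
Compound 2 `Cn1ncc(Cl)c1-c1cc(C(=O)N[C@@H]2CN[C@H](CCN3CCC(O)CC3)C[C@H]2c2ccc(Cl)c(Cl)c2)oc1Cl` gives 13700 nM
Compound 3 `Cn1ncc(Cl)c1-c1cc(C(=O)N[C@@H]2CN[C@H](CC(=O)O)C[C@H]2c2ccc(Cl)c(Cl)c2)oc1Cl` gives 4020 nM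

Compound 3 stands in the middle of these three numbers. Compound 4 `Cn1ncc(Cl)c1-c1cc(C(=O)N[C@@H]2CN[C@H](CC(=O)NCC(O)CO)C[C@H]2c2ccc(Cl)c(Cl)c2)oc1Cl` differs from it by (2,3-dihydroxypropyl)amino in place of hydroxy on a carbonyl carbon. Among the measured compounds shown here, no measured step makes this exact change. The closest guide is compound 1, which also has a dihydroxy chain end and lies lower, as the step of a 3.6-fold higher number from compound 1 to compound 3 (0.56 log units; beyond the scatter) shows. The opposite comparison, a 3.4-fold lower number from compound 2 to compound 3 (0.53 log units; beyond the scatter), involves a piperidine-bearing chain and says less here. A modest fall in this assay is therefore expected, with the expected step being a 2.1-fold lower number from compound 3 to compound 4 (0.33 log units; beyond the scatter). For compound 4 the estimated value is 1900 nM, within an expected range of 700 nM to 5500 nM.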

Compound 4, half-maximal inhibitory concentration: 7090 nM
Beside the measured number, compound 4's estimate is 3.7-fold (0.57 log units) below it, outside the stated range (above it).
By their numbers in this assay, from the lowest: compound 1; then compounds 3, 4 and 2 (each within the scatter of the next, the first and the last beyond it).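

In this assay, turning the carboxy end into the (2,3-dihydroxypropyl)carbamoyl end leaves the number within the scatter, with a 1.8-fold higher number from compound 3 to compound 4 (0.25 log units; within the scatter), and the same holds against the piperidine-bearing chain, with a 1.9-fold lower number from compound 2 to compound 4 (0.29 log units; within the scatter). A dihydroxy end alone therefore does not fix the number at this position, since 1,2-dihydroxyethyl and (2,3-dihydroxypropyl)carbamoyl differ beyond the scatter, with a 6.4-fold higher number from compound 1 to compound 4 (0.81 log units; beyond the scatter). Nothing available explains this difference. On these data alone, what a plain carbamoyl or a primary amine would give at this chain end remains open.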